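Aryl amide variation on the indole azo series

A few compounds are considered here, and "the series" means these few. Any claim that something is new, unique, unknown or untested is made for them only; others in the source may bear on it.

Measured compounds:
- Compound 1, `O=C(Nc1ccccc1[N+](=O)[O-])c1ccc(/N=N\c2c[nH]c3ccccc23)cc1`; in a functional assay on P388 cells (Mus musculus) for inhibition, read by MTT assay, with a stated time of 72 h (a higher number here means a weaker inhibitor, a lower number a stronger inhibitor), compound 1 gives 77900 nM.
- Compound 2, `Cc1ccc(NC(=O)c2ccc(/N=N\c3c[nH]c4ccccc34)cc2)c(C)c1`; in this assay compound 2 gives 190000 nM.

Compound 2 holds the highest number of the two measured; its nearest neighbour is compound 1, and the step of a 2.4-fold higher number from compound 1 to compound 2 (0.39 log units; beyond the scatter) lies beyond the scatter. Compound 3, `O=C(Nc1ccc(Cl)cc1)c1ccc(/N=N\c2c[nH]c3ccccc23)cc1`, is not yet measured. It differs from compound 2 as follows: 4-chlorophenyl in place of 2,4-dimethylphenyl on an amide-type nitrogen. Within the data shown here, only one measured step concerns the same position on the amide-type nitrogen, namely a 2.4-fold higher number from compound 1 to compound 2 (0.39 log units; beyond the scatter), a modest move between two different aryl groups. Among the measured compounds shown here, no measured pair speaks directly to 4-chlorophenyl, so the expectation for compound 3 rests on the spread that the single step shows. Since the two measured aryl amides sit a modest distance apart, compound 3 is expected to fall in the same broad region, probably with a number somewhat lower than compound 2 but not beyond the width of that one step. The estimated step is a 1.7-fold lower number from compound 2 to compound 3 (0.24 log units; within the scatter). For compound 3 the expected value in this assay is 110000 nM, with a range from 40000 nM to 300000 nM.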

Compound 3, half-maximal inhibitory concentration: 80000 nM
Compound 3: middle estimate off by 1.4-fold (0.14 log units), on the high side, and the stated range covers the measured number.
By their numbers in this assay, from the lowest: compounds 1 and 3 (each within the scatter of the next); then compound 2.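

In this assay, 4-chlorophenyl in place of 2,4-dimethylphenyl on the amide-type nitrogen gives a 2.4-fold lower number from compound 2 to compound 3 (0.38 log units; beyond the scatter), so the position now shows a second change of about the same size as the first. 2-Nitrophenyl and 4-chlorophenyl are different groups, yet a 1.0-fold higher number from compound 1 to compound 3 (0.01 log units; within the scatter) leaves them indistinguishable, and among these three compounds only compound 2, with its 2,4-dimethylphenyl, stands apart from the others. Nothing in hand offers an explanation for this separation or connects it to any property of the groups.

Going by these compounds, all three compounds carry a substituted phenyl on the amide-type nitrogen, so it remains open how a plain phenyl, a cyclohexyl or a chain ending in an amine or a carboxylic acid would read at this position. Also open, on these data alone, is whether 2,4-dimethylphenyl stands apart through its methyl groups as such or through their placement, a question that 4-methylphenyl and 2-methylphenyl would bear on directly.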